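From 4-methylphenyl to 2-methylphenyl in compound 4

The source may hold more compounds than are shown below. What is called first, only, known or untested is meant among the compounds shown, and "the series" means these compounds.

In a functional assay on PANC-1 cells (Homo sapiens) for inhibition, read by MTT assay, with a stated time of 24 h (a higher number here means a weaker inhibitor, a lower number a stronger inhibitor), compound 1 `CC1(C)[C@H]2CC[C@]1(C)N(Cc1cn(-c3ccccc3Br)nn1)C(=O)C2` reads 280 nM and compound 2 `CC1(C)[C@H]2CC[C@]1(C)N(Cc1cn(-c3ccccc3F)nn1)C(=O)C2` reads 150 nM while compound 3 `Cc1ccc(-n2cc(CN3C(=O)C[C@@H]4CC[C@@]3(C)C4(C)C)nn2)cc1` sits at 270 nM within the scatter of both others. Within the data shown here, compound 4 `Cc1ccccc1-n1cc(CN2C(=O)C[C@@H]3CC[C@@]2(C)C3(C)C)nn1` has not yet been measured and carries 2-methylphenyl in place of 4-methylphenyl on an aromatic nitrogen as its only change from compound 3. Among the measured compounds shown here, three measured steps bear on this. Replacing the aryl group gave a 1.0-fold lower number from compound 1 to compound 3 (0.02 log units; within the scatter) and a 1.8-fold higher number from compound 2 to compound 3 (0.26 log units; within the scatter) while fluoro in place of bromo gave a 1.9-fold lower number from compound 1 to compound 2 (0.27 log units; within the scatter) so none left the scatter. No step beyond the scatter is therefore expected in this assay for this move. What is expected is a 1.2-fold lower number from compound 3 to compound 4 (0.09 log units; within the scatter) by estimate. Compound 4 is expected at an estimated 220 nM (range 100 nM to 480 nM).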

Compound 4, half-maximal inhibitory concentration: 250 nM
Compound 4: middle estimate off by 1.1-fold (0.06 log units), on the low side; measured number inside the range.
By their numbers in this assay, from the lowest: compounds 2, 4, 3 and 1 (each within the scatter of the next).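

In this assay moving the methyl from 4-methylphenyl to 2-methylphenyl gives a 1.1-fold lower number from compound 3 to compound 4 (0.03 log units; within the scatter) and so the place of the methyl on this ring makes no difference that can be read here. Methyl on the ring carbon that carries the halogen in the earlier compounds also stays within the scatter, with a 1.7-fold higher number from compound 2 to compound 4 (0.22 log units; within the scatter) and a 1.1-fold lower number from compound 1 to compound 4 (0.05 log units; within the scatter) as the two steps. Nothing measured here explains why these groups read alike. Still open, on these data alone, is whether an amine or a carboxylic acid on this ring, or a longer chain in place of the methyl, would move the number beyond the scatter.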